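The compounds below may be only part of what the source reports. "The series", "measured", "known", "first", "only" and "open" are said of these compounds alone.

Compound 2 `CCNC(=O)Nc1ccc(Nc2ncnc3cc(OCC4CCN(C)CC4)ccc23)cc1` carries a urea whose outer nitrogen bears an ethyl group. Among the measured compounds shown here, in a functional assay on HUVEC cells (Homo sapiens) for antiproliferative activity, read by sulforhodamine B assay, with a stated time of 48 h (on this read-out lower numbers stand for stronger inhibition and higher numbers for weaker inhibition), compound 2 gives 587 nM, the higher of the two numbers measured so far. Compound 1 `COc1cc2c(Nc3ccc(NC(=O)Nc4cccc(F)c4)cc3)ncnc2cc1OCC1CCN(C)CC1`, which carries an aromatic group on that urea nitrogen, gives 179 nM in this assay, a gap beyond the scatter. Compound 3 `Cc1ccc(NC(=O)Nc2ccc(Nc3ncnc4cc(OCC5CCN(C)CC5)ccc34)cc2)cc1Br` differs from compound 2 by 3-bromo-4-methylphenyl in place of ethyl on an amide-type nitrogen. For the measured compounds named here, no measured pair isolates exactly this change, but on the showing of compound 1 the expected step is a 3.9-fold lower number from compound 2 to compound 3 (0.59 log units; beyond the scatter), beyond the scatter and toward a lower number. Compound 3 is therefore estimated at 150 nM, within a range from 50 nM to 450 nM.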

Compound 3, half-maximal inhibitory concentration: 196 nM
Beside the measured number, compound 3's estimate is 1.3-fold (0.12 log units) below it, and the stated range covers the measured number.
By their numbers in this assay, from the lowest: compounds 1 and 3 (each within the scatter of the next); then compound 2.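

Here, for the first time, two compounds differ in one place only, so the urea nitrogen can be judged on its own. In this assay, 3-bromo-4-methylphenyl in place of ethyl on this nitrogen gives a 3.0-fold lower number from compound 2 to compound 3 (0.48 log units; beyond the scatter) and shows that the number responds to the group held there. Nothing at hand explains why the number moves.

From the compounds shown here alone, what a plain phenyl or a longer chain such as butyl would give on this nitrogen stays open. The step therefore cannot yet be divided among the ring, the bromine and the methyl.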